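A few compounds are considered here, and "the series" means these few. Any claim that something is new, unique, unknown or untested is made for them only; others in the source may bear on it.

- Compound 1 `CC1(C)[C@H]2CC[C@]1(C)N(Cc1cn(-c3ccccc3F)nn1)C(=O)C2`: 240 nM
- Compound 2 `CC1(C)[C@H]2CC[C@]1(C)N(Cc1cn(-c3ccccc3Cl)nn1)C(=O)C2`: 70 nM

Both values come from a functional assay on A549 cells (Homo sapiens) for inhibition, read by MTT assay, with a stated time of 24 h; on this read-out higher numbers stand for weaker inhibition and lower numbers for stronger inhibition. Among the measured compounds shown here, compound 2 stands at 70 nM, the lower of the two numbers so far. Compound 3 `COc1ccccc1-n1cc(CN2C(=O)C[C@@H]3CC[C@@]2(C)C3(C)C)nn1` has methoxy in place of chloro on an aromatic carbon, ortho to a large group, and so differs from compound 2 as follows: methoxy in place of chloro on an aromatic carbon.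

For the measured compounds named here, only one measured step bears on this change, the swap of fluoro for chloro on that same carbon: a 3.4-fold lower number from compound 1 to compound 2 (0.54 log units; beyond the scatter). That modest step, beyond the scatter, shows that this group can shift the number. Going by the values given here, no methoxy compound has been measured, so the direction remains uncertain. Among the compounds with values here, since compound 2 holds the lowest number so far, a modest move upward seems likelier. The expected change is a 2.0-fold higher number from compound 2 to compound 3 (0.30 log units; within the scatter). For compound 3 the estimated value is 140 nM, with an expected range of 45 nM to 450 nM.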

Compound 3, half-maximal inhibitory concentration: 350 nM
The estimate for compound 3 lay 2.5-fold (0.40 log units) below the measured number, within the range that was stated.
By their numbers in this assay, from the lowest: compound 2; then compounds 1 and 3 (each within the scatter of the next).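

The change to methoxy brings a 5.0-fold higher number from compound 2 to compound 3 (0.70 log units; beyond the scatter) and so the low number seen with chloro does not carry over to a group with more heavy atoms and a hydrogen-bond acceptor. Methoxy and fluoro cannot be told apart, with a 1.5-fold higher number from compound 1 to compound 3 (0.16 log units; within the scatter) and so, of the three groups shown on this carbon, only chloro stands apart from the other two. Nothing measured here gives a reason for this difference.

As far as these compounds go, whether chloro is unique remains open: bromo, methyl or trifluoromethyl on the same carbon would show if other groups share its low number, and an amine would test a very different kind of group. Also open, from the compounds shown here alone, is whether chloro keeps its edge when other parts of the shared core change.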